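A few compounds are considered here, and "the series" means these few. Any claim that something is new, unique, unknown or untested is made for them only; others in the source may bear on it.

Compound 2 `OCCOCn1cc2ccnc-2nc1O` gives in a functional assay on HEL cells (Homo sapiens), read by microscopy (on this read-out higher numbers stand for lower toxicity in this test and lower numbers for higher toxicity in this test), only a limit, > 400000 nM, rather than a number. Compound 1 `CCCCCCCCCc1cc2cn(COCCO)c(O)nc-2n1` likewise stops at a limit, > 80000 nM, in this assay. Both values shown are limits, so compound 2 cannot be placed against any measured number. Compound 3 `CCCCCc1cc2cn(COCCO)c(O)nc-2n1` is still to be measured; it differs from compound 2 by pentyl in place of hydrogen on an aromatic carbon. Among the measured compounds shown here, with no measured step available, no shift beyond the scatter is expected in this assay; the expected step is an at least 2.0-fold lower number from compound 2 to compound 3 (0.30 log units; that floor lies within the scatter). Compound 3 is estimated at 200000 nM, between 80000 nM and 600000 nM, and will most likely again be reported as a limit.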

Compound 3, minimum cytotoxic concentration: > 400000 nM
Compound 3 gave a limit, no number; the forecaster's own chance of this, stated with the estimate: 80%; at least 2.0-fold (0.30 log units) between middle value and limit.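

In this assay, among the compounds shown here, compound 1, compound 2 and compound 3 all give limits rather than numbers, so no step between them can be read. The compounds shown leave open at what concentration each becomes toxic, and whether pentyl in place of hydrogen changes that.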